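Chain Extension on a Triazole-Bearing Lactone Core

The source may hold more compounds than are shown below. What is called first, only, known or untested is meant among the compounds shown, and "the series" means these compounds.

Compound 1 `CCCCc1cn(C[C@H](O)[C@H]2OC(=O)C(OCc3ccccc3)=C2OCc2ccccc2)nn1` gives 26300 nM in an ADME assay on HFF cells (Homo sapiens) for cytotoxicity, read by MTT assay, with a stated time of 72 h (on this read-out higher numbers stand for weaker inhibition and lower numbers for stronger inhibition), the higher of the two plain numbers recorded there. Compound 2 `CC(C)(C)OC(=O)N1CCN(C(=S)SCc2cn(C[C@H](O)[C@H]3OC(=O)C(OCc4ccccc4)=C3OCc3ccccc3)nn2)CC1` gives 60 nM in this assay, a far lower number. For compound 3 `O=C1O/C(=C\Cn2cc(-c3cc(C(F)(F)F)cc(C(F)(F)F)c3)nn2)C(OCc2ccccc2)=C1OCc1ccccc1` this assay reports only a limit, > 100000 nM, and no number. Compound 4 `CCCCCCCCCCc1cn(C[C@H](O)[C@H]2OC(=O)C(OCc3ccccc3)=C2OCc2ccccc2)nn1` has not yet been measured; it differs from compound 1 by hexyl in place of hydrogen on a saturated chain carbon, four bonds along the chain from an aromatic carbon. Within the data shown here, no step between measured compounds of this kind is available. A number for a longer chain on the shared core has not yet been recorded in this assay. The account expects a moderate shift toward a lower number, somewhat beyond the usual scatter, as a 3.3-fold lower number from compound 1 to compound 4 (0.52 log units; beyond the scatter). Compound 4 is therefore estimated at 8000 nM, with a range from 2000 nM to 40000 nM.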

Compound 4, half-maximal inhibitory concentration: > 100000 nM
Compound 4: a limit, no number (the forecaster's own chance of this, stated with the estimate: 10%); at least 12-fold (1.09 log units) between middle value and limit.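

In this assay, hexyl in place of hydrogen on a saturated chain carbon, four bonds along the chain from an aromatic carbon, gives an at least 3.8-fold higher number from compound 1 to compound 4 (0.58 log units; beyond the scatter). Among these compounds, this is the first step at this position, and it runs toward a higher number. Going by these compounds, the value of compound 4 is a limit and not a number, so the full size of the step stays unknown: the limit of > 100000 nM in this assay, at which 2 of the 4 values shown sit.

On these data alone, what a shorter chain, an amine or a carboxylic acid would give at this position stays open. A single step also cannot tell how the number follows chain length.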